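The compounds below may be only part of what the source reports. "The series", "measured", "known", "first", "only" and "open" are said of these compounds alone.

- compound 1 `COc1ccc(-n2ccc3c(OC)c(OC)c(OC)cc32)cc1`: 198 nM
- compound 2 `COc1ccc(-n2ccc3c(OC)c(OC)c(OC)cc32)c(N)c1`: 96 nM
- compound 3 `COc1ccc(-n2ccc3c(OC)c(OC)c(OC)cc32)cc1N`: 2390 nM

All three values come from a functional assay on NCI-H460 cells (Homo sapiens) for antiproliferative activity, with a stated time of 72 h; a higher number here means a weaker inhibitor, a lower number a stronger inhibitor. Of these, compound 3 gives the highest number, 2390 nM, which makes it the weakest inhibitor of the three.

The next compound, compound 4 `COc1ccc(-n2ccc3c(OC)c(OC)c(OC)cc32)cc1O`, keeps the same core but has hydroxy in place of amino on an aromatic carbon, ortho to a methoxy group: hydroxy in place of amino on an aromatic carbon.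

Among the compounds with values here, two measured steps bear on this change, though neither swaps amino for hydroxy. Placing amino on that same carbon in place of hydrogen gave a 12-fold higher number from compound 1 to compound 3 (1.08 log units; beyond the scatter), a large loss. Placing amino on a different carbon gave a 2.1-fold lower number from compound 1 to compound 2 (0.31 log units; beyond the scatter), a modest gain. The number therefore depends strongly on where the amino group sits, and this carbon is the costly site. How hydroxy behaves there has not been measured.

Since compound 1, with only hydrogen at this carbon, gives 198 nM, removing the amino group may recover part of that loss, but probably not all of it. The expected change is a moderate fall, stated as a 2.4-fold lower number from compound 3 to compound 4 (0.38 log units; beyond the scatter), with real uncertainty about its size. For compound 4 the estimated value is 1000 nM, with an expected range from 200 nM to 4000 nM.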

Compound 4, half-maximal inhibitory concentration: 737 nM
The estimate for compound 4 lay 1.4-fold (0.13 log units) above the measured number, within the range that was stated.
By their numbers in this assay, from the lowest: compound 2; then compound 1; then compound 4; then compound 3.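

In this assay the swap of amino for hydroxy gives a 3.2-fold lower number from compound 3 to compound 4 (0.51 log units; beyond the scatter) and so shows that the number at this carbon depends on which group sits there, not only on whether a group is present. Even so, putting hydroxy in place of hydrogen gives a 3.7-fold higher number from compound 1 to compound 4 (0.57 log units; beyond the scatter) and so places hydroxy with amino: on this carbon, both groups give a higher number than plain hydrogen, though hydroxy costs less. No evidence is available to explain the difference between these groups.

The compounds shown leave open whether any other group on this carbon, such as a fluorine atom, a methyl group or a carboxylic acid, could match hydrogen or improve on it. From the compounds shown here alone, they also leave open how hydroxy would behave on the other carbon, where amino in compound 2 gave the lower number, so it remains unknown whether the two groups would rank the same way at that site.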